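Cytotoxicity notes on a vinyl dihydrofuran amide series

The source may report more compounds than this note shows. Statements on the series, on what has been measured and on what is new or still open speak of the compounds shown alone.

Measured so far:
compound 1 `C=CC1=C(C(=O)NCc2ccccc2)C(c2ccc(OC)cc2)OC1` gives > 100000 nM in a functional assay on A549 cells (Homo sapiens) for cytotoxicity, read by MTT assay, with a stated time of 24 h; on this read-out higher numbers stand for weaker inhibition and lower numbers for stronger inhibition
compound 2 `C=CC1=C(C(=O)Nc2ccccc2)C(c2ccc(Cl)c(Cl)c2)OC1` gives > 100000 nM in this assay

For compound 1 the value in this assay is only a limit, not a number. For compound 2 the value in this assay is likewise only a limit. Within the data shown here, both values shown sit at the limit of > 100000 nM in this assay, at which 2 of the 2 values shown sit, so no step between measured compounds can be computed and compound 2 stands at that limit. Compound 3 `C=CC1=C(C(=O)NCc2ccccc2)C(c2ccc(Cl)c(Cl)c2)OC1` differs from compound 2 by benzyl in place of phenyl on an amide-type nitrogen. Among the measured compounds shown here, with no measured step available, no shift beyond the scatter is expected; the estimated step is a number no higher from compound 2 to compound 3 (the limit leaves the size open). Compound 3 is therefore expected near 100000 nM, within 30000 nM to 300000 nM, most probably again reported only as a limit.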

Compound 3, half-maximal inhibitory concentration: > 100000 nM
Compound 3 was reported as a limit (the forecaster's own chance of this, stated with the estimate: 80%); the middle value lies on the limit itself.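

No new step can be read among compound 1, compound 2 and compound 3, because each value is only a limit: the limit of > 100000 nM in this assay, at which 3 of the 3 values shown sit. The compounds shown leave open whether benzyl versus phenyl on the amide-type nitrogen, or 3,4-dichlorophenyl versus 4-methoxyphenyl on the saturated ring carbon, changes cytotoxicity at all.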